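Moving the Fluoro Group: 2-Fluorophenyl to 3-Fluorophenyl

The source may hold more compounds than are shown below. What is called first, only, known or untested is meant among the compounds shown, and "the series" means these compounds.

In an ADME assay on MT4 cells (Homo sapiens) for cytotoxicity, read by MTT assay, with a stated time of 4 days (on this read-out lower numbers stand for higher toxicity in this test and higher numbers for lower toxicity in this test), compound 1 (`COc1c(-c2ccccc2)oc2ccc(NC(C)=O)cc2c1=O`) gives 200000 nM and compound 2 (`COc1cccc(-c2oc3ccc(NC(C)=O)cc3c(=O)c2OC)c1`) gives 369000 nM. Compound 3 (`COc1c(-c2ccccc2F)oc2ccc(NC(C)=O)cc2c1=O`) gives 180000 nM, which stands within the scatter of compound 1. Against compound 2 there is a modest gap, a 2.1-fold lower number from compound 2 to compound 3 (0.31 log units; beyond the scatter).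

Compound 4 (`COc1c(-c2cccc(F)c2)oc2ccc(NC(C)=O)cc2c1=O`) awaits measurement. It carries 3-fluorophenyl in place of 2-fluorophenyl on an aromatic carbon, with the same atoms joined differently: 3-fluorophenyl in place of 2-fluorophenyl on an aromatic carbon.

For the measured compounds named here, no measured step shows this exchange directly, so the evidence is indirect. Fluoro in place of hydrogen gave a 1.1-fold lower number from compound 1 to compound 3 (0.05 log units; within the scatter), and methoxy in place of hydrogen gave a 1.8-fold higher number from compound 1 to compound 2 (0.27 log units; within the scatter). Going by the values given here, both steps stay within the scatter, and the one step beyond it, from compound 2 to compound 3, is modest and changes a different substituent. No step beyond the scatter is therefore expected, and the direction is uncertain. The expected change is small, a 1.2-fold higher number from compound 3 to compound 4 (0.09 log units; within the scatter). Compound 4 is estimated at 220000 nM, with an expected range from 120000 nM to 400000 nM.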

Compound 4, half-maximal cytotoxic concentration: 210000 nM
For compound 4 the middle estimate is 1.0-fold (0.02 log units) above the measured one, and the stated range covers the measured number.
By their numbers in this assay, from the lowest: compounds 3, 1, 4 and 2 (each within the scatter of the next, the first and the last beyond it).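

Moving the fluoro group from 2-fluorophenyl to 3-fluorophenyl, with the same atoms joined differently, left the number in this assay within the scatter, with a 1.2-fold higher number from compound 3 to compound 4 (0.07 log units; within the scatter). For the compounds shown here, this gives the first direct reading at this position of a fluoro group's placement on the ring, and at this pair of placements the read-out does not separate the two. The 3-fluorophenyl group also stays within the scatter of both the phenyl and the 3-methoxyphenyl groups, with a 1.1-fold higher number from compound 1 to compound 4 (0.02 log units; within the scatter) and a 1.8-fold lower number from compound 2 to compound 4 (0.24 log units; within the scatter), whereas a 2.1-fold lower number from compound 2 to compound 3 (0.31 log units; beyond the scatter) lay beyond it. Nothing measured alongside these numbers bears on what lies behind them.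

On these data alone, it remains open whether a phenyl carrying an amine or a carboxylic acid in place of the fluoro group would stay this close. Only the group at this one place varies among the four compounds, so nothing is shown about changes elsewhere on the shared core.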